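The source may report more compounds than this note shows. Statements on the series, on what has been measured and on what is new or still open speak of the compounds shown alone.

Measured so far:
- Compound 2 `Cc1ccc(C(=O)N[C@H]2CCN(Cc3ccc(OCCCN(C)C)cc3)C2)cc1C`: < 10000 nM
- Compound 1 `Cc1cc(C(=O)N[C@H]2CCN(Cc3ccc(OCCCN(C)C)cc3)C2)ccc1Cl`: 631 nM
- Compound 3 `CN(C)CCCOc1ccc(CN2CC[C@H](NC(=O)c3ccncc3)C2)cc1`: < 10000 nM

In an assay on HEK293 cells for binding affinity to Urotensin-2 receptor (Homo sapiens), read by radioligand binding (a higher number here means a weaker inhibitor, a lower number a stronger inhibitor), compound 2 is known only through a limit of the assay, < 10000 nM, not a number. Compound 3 likewise reaches only a limit, < 10000 nM. Compound 1 gives 631 nM. Compound 4, `CN(C)CCCOc1ccc(CN2CC[C@H](NC(=O)c3ccc4ccccc4c3)C2)cc1`, differs from compound 2 in one place: naphthalen-2-yl in place of 3,4-dimethylphenyl on a carbonyl carbon. The steps that touch compound 2 cannot be sized: a step that the limit leaves unreadable from compound 1 to compound 2 and a step that the two limits leave unreadable from compound 2 to compound 3, both hidden by the limit of < 10000 nM in this assay, at which 2 of the 3 values shown sit. The change toward compound 4 has no measured counterpart among these compounds, so no direction beyond the scatter can be foreseen. Compound 4 is expected to give about 1500 nM, between 200 nM and 10000 nM. The step expected from this estimate is a step that the limit leaves unreadable from compound 2 to compound 4, held with little confidence.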

Compound 4, inhibition constant: < 10000 nM
Compound 4: no number, only a limit; the forecaster's own chance of this, stated with the estimate: 30%; the middle value is on the limit's open side.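

Compound 4 gives only a limit of the assay, not a number, so no step linking it to compound 1, compound 2 or compound 3 can be read: the limit of < 10000 nM in this assay, at which 3 of the 4 values shown sit.

Still open, from the compounds shown here alone, is how naphthalen-2-yl on the carbonyl carbon compares with 3,4-dimethylphenyl, pyridin-4-yl or 4-chloro-3-methylphenyl.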